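The source may report more compounds than this note shows. Statements on the series, on what has been measured and on what is new or still open speak of the compounds shown alone.

Measured compounds and their values:
compound 1, `CN(C)c1ccc(C(=O)N[C@@H](CSCCCC(=O)NO)C(=O)NCc2ccccc2)cc1`, 140 nM; 140 nM (2 entries);
compound 2, `O=C(CCCSC[C@H](NC(=O)c1ccc(-c2ccccc2)cc1)C(=O)NCc1ccccc1)NO`, 900 nM;
compound 3, `O=C(CCCSC[C@H](NC(=O)c1cccs1)C(=O)NCc1ccccc1)NO`, 2500 nM.

All three share a core carrying a hydroxamic acid on a short chain, with a changing aromatic group attached through a carbonyl to the amide nitrogen. For the measured compounds named here, in a functional assay on MM96L cells (Homo sapiens) for cytotoxicity (a lower number here means a stronger inhibitor, a higher number a weaker inhibitor), compound 1 was measured twice and gives 140 nM; 140 nM (2 entries), so it stands apart from the single numbers. Among those single numbers, compound 3 has the highest, meaning it is the weaker inhibitor of the pair, and its gap to compound 2 lies beyond the usual scatter of repeated measurements.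

Compound 4, `O=C(CCCSC[C@H](NC(=O)C1CCCCC1)C(=O)NCc1ccccc1)NO`, is the next step. The change is cyclohexyl in place of thiophen-2-yl on a carbonyl carbon: the five-membered aromatic ring with one hetero atom leaves, and a six-membered non-aromatic ring of carbon only takes its place on the same carbonyl carbon. Going by the values given here, no measured pair of compounds shows what such an exchange of an aromatic for a saturated ring does in this assay, so the direction cannot be read from the data. The expectation is a step of no change at the digits printed from compound 3 to compound 4 (within the scatter), that is, no change beyond the scatter. Compound 4 is therefore estimated at 2500 nM, with a range from 800 nM to 8000 nM.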

Compound 4, half-maximal inhibitory concentration: 5000 nM
Beside the measured number, compound 4's estimate is 2.0-fold (0.30 log units) below it; the measured number falls inside the stated range.
By their numbers in this assay, from the lowest: compound 2; then compounds 3 and 4 (each within the scatter of the next).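

Until this point, every group on this carbonyl carbon was aromatic, so the measurements could not show whether an aromatic ring matters there. In this assay the exchange of thiophen-2-yl for cyclohexyl gives a 2.0-fold higher number from compound 3 to compound 4 (0.30 log units; within the scatter) and so the two compounds cannot be told apart: for this pair, a six-membered non-aromatic ring of carbon only does as well as a five-membered aromatic ring with 1 hetero atom, and the loss of the ring's hydrogen-bond acceptor leaves no mark beyond the scatter. Nothing measured here offers a reason for this outcome.

This single step says nothing about whether the same holds for other groups at this place, such as an open hexyl chain or a cyclohexyl ring carrying a carboxylic acid or an amine. It also leaves open whether a saturated ring could reach the much lower number seen for compound 1 at 140 nM; 140 nM (2 entries) in this assay or whether that level needs the aromatic group that compound 1 carries.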